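The source may report more compounds than this note shows. Statements on the series, on what has been measured and on what is new or still open speak of the compounds shown alone.

Working notes on the series. Compound 1 `Cc1ccccc1-n1cc(-c2cccc(NS(=O)(=O)c3c[nH]c(=O)[nH]c3=O)c2)nn1` carries 2-methylphenyl on an aromatic nitrogen; in a functional assay on SGC-7901 cells (Homo sapiens) for antiproliferative activity, read by MTT assay, with a stated time of 24 h (on this read-out lower numbers stand for stronger inhibition and higher numbers for weaker inhibition), compound 1 gives 9230 nM. Compound 2 `O=c1[nH]cc(S(=O)(=O)Nc2cccc(-c3cn(-c4ccc(F)cc4)nn3)c2)c(=O)[nH]1` carries 4-fluorophenyl at that position; in this assay compound 2 gives > 20000 nM, which is a limit of the assay and not a number. The change amounts to an at least 2.1-fold higher number from compound 1 to compound 2 (0.33 log units; beyond the scatter). Compound 3 `O=c1[nH]cc(S(=O)(=O)Nc2ccc(-c3cn(-c4cccc(F)c4)nn3)cc2)c(=O)[nH]1` carries 3-fluorophenyl there; in this assay compound 3 gives > 20000 nM, again a limit of the assay. Compound 3 thus stands at the limit of > 20000 nM in this assay, at which 2 of the 3 values shown sit, and only compound 1 has a number inside the measured range.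

Compound 4 `O=c1[nH]cc(S(=O)(=O)Nc2ccc(-c3cn(-c4ccc(Cl)cc4)nn3)cc2)c(=O)[nH]1` differs from compound 3 by 4-chlorophenyl in place of 3-fluorophenyl on an aromatic nitrogen. Among the compounds with values here, no measured step exchanges one halogen for another or moves a substituent around the phenyl ring; the only measured step, which was at least modest, runs toward that limit, where compound 3 also sits. No step beyond the scatter is therefore expected in this assay. Compound 4 is expected near 25000 nM (range 10000 nM to 60000 nM), which means an expected step that the limit leaves unreadable from compound 3 to compound 4, most likely reported once more only as a limit.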

Compound 4, half-maximal inhibitory concentration: 1830 nM
Compound 4: the middle estimate sits 14-fold (1.14 log units) above what was measured, and the stated range ends above it.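

In this assay, within the data shown here, the exchange of 3-fluorophenyl for 4-chlorophenyl on the aromatic nitrogen gives an at least 10-fold lower number from compound 3 to compound 4 (1.03 log units; beyond the scatter) and so shows that this position can move the read-out toward stronger inhibition, whereas the one earlier readable step ran toward weaker inhibition. The two groups have the same heavy-atom count. Their counted donors, acceptors and charge do not differ. The step remains a bound and not a number, because compound 3 is held at a limit of the assay: the limit of > 20000 nM in this assay, at which 2 of the 4 values shown sit.

The halogen and its place on the phenyl ring change together in this single step, and the compounds shown do not separate the two. On these data alone, how 4-bromophenyl, 4-methoxyphenyl or a phenyl bearing a carboxylic acid would read at this position remains open.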